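Methoxy addition on two cores in HeLa cell growth

A few compounds are considered here, and "the series" means these few. Any claim that something is new, unique, unknown or untested is made for them only; others in the source may bear on it.

In a functional assay on HeLa cells (Homo sapiens) for inhibition, read by cell counting, with a stated time of 4 days (on this read-out higher numbers stand for weaker inhibition and lower numbers for stronger inhibition), compound 1 `COc1ccc(-c2nn3cc(-c4cccc(N)c4)nc3s2)cc1OC` gives 26000 nM and compound 2 `Nc1cccc(-c2cn3c(-c4ccccc4)csc3n2)c1` gives 60000 nM. Compound 3 `COc1ccc(-c2nn3cc(-c4cccc(N)c4)nc3s2)cc1` reaches only a limit in this assay, >= 250000 nM, as noted at the limit of >= 250000 nM in this assay, at which 1 of the 3 values shown sits. The measured step methoxy in place of hydrogen on an aromatic carbon gives an at least 9.6-fold lower number from compound 3 to compound 1 (0.98 log units; beyond the scatter). Compound 4 `COc1ccc(-c2csc3nc(-c4cccc(N)c4)cn23)cc1` has not been measured; it differs from compound 2 by methoxy in place of hydrogen on an aromatic carbon. This is the same kind of change, not the same: in the step from compound 3 to compound 1 the new methoxy sits ortho to a methoxy group and meta to a large group, whereas in compound 4 it sits para to a large group, and the difference between the two cores is not broken down here. Going by these compounds, a single methoxy on the core of compound 3 sits at the limit, so what that first methoxy does is unknown. A smaller step than the measured one is therefore expected; compound 4 is estimated at a 2.4-fold lower number from compound 2 to compound 4 (0.38 log units; beyond the scatter) from compound 2, resting on 60000 nM of compound 2. Compound 4 is expected to fall near 25000 nM in this assay, roughly between 8000 nM and 120000 nM.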

Compound 4, half-maximal inhibitory concentration: 19000 nM
Beside the measured number, compound 4's estimate is 1.3-fold (0.12 log units) above it; measured number inside the range.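

In this assay, methoxy in place of hydrogen on an aromatic carbon lowers the number on both cores, with a 3.2-fold lower number from compound 2 to compound 4 (0.50 log units; beyond the scatter) as the new step. The direction of the change carries across these two cores, but its size does not: the same change on two cores in this assay, an at least 9.6-fold lower number (0.98 log units; beyond the scatter) from compound 3 to compound 1 and a 3.2-fold lower number (0.50 log units; beyond the scatter) from compound 2 to compound 4, at least 3.0-fold (0.48 log units) apart, beyond the scatter of two such steps

Compound 3 stands at >= 250000 nM, which is a limit of the assay and not a number, so the earlier step has no exact size, and with both the core and the place of the methoxy differing, the two steps cannot separate the contribution of the core from that of the place on the ring.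

Still open, going by these compounds, is whether a second methoxy on the core of compound 4 would lower the number further, as the pair on the other core might suggest. Also open, on these data alone, is whether ethoxy, a carboxylic acid or a dimethylamino group, para to a large group on the same ring, would give a step like that of methoxy.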